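Moving a Methoxy Group on a Weak Sulfonamide Series

A few compounds are considered here, and "the series" means these few. Any claim that something is new, unique, unknown or untested is made for them only; others in the source may bear on it.

Of the compounds shown here, three sharing one core have been tested in an assay on cells for inhibition of HSP60/HSP10 (Homo sapiens), with a stated time of 60 min; a higher number here means a weaker inhibitor, a lower number a stronger inhibitor. Compound 1 `O=S(=O)(Nc1ccc(-c2nc3ccccc3o2)cc1)c1cccc(F)c1` gives 71000 nM in this assay, and compound 3 `O=S(=O)(Nc1ccc(-c2nc3ccccc3o2)cc1)c1ccc(O)cc1` gives 78000 nM. Compound 2 `CS(=O)(=O)Nc1ccc(-c2nc3ccccc3o2)cc1` reaches only a limit of this assay, > 100000 nM. Compound 3 thus holds the highest of the two numbers, though only narrowly, as a 1.1-fold higher number from compound 1 to compound 3 (0.04 log units; within the scatter) shows. Compound 4 `COc1cccc(S(=O)(=O)Nc2ccc(-c3nc4ccccc4o3)cc2)c1` differs from compound 3 by 3-methoxyphenyl in place of 4-hydroxyphenyl on a sulfonyl sulfur. The changes already measured at that sulfonyl sulfur were small: a 1.1-fold higher number from compound 1 to compound 3 (0.04 log units; within the scatter) and an at least 1.2-fold lower number from compound 2 to compound 3 (0.10 log units; that floor lies within the scatter). A further swap at the same position is therefore expected to shift the number little, if at all, giving an estimated 1.0-fold lower number from compound 3 to compound 4 (0.02 log units; within the scatter). For compound 4 the expected value in this assay is 75000 nM, within a range from 30000 nM to 200000 nM.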

Compound 4, half-maximal inhibitory concentration: 80000 nM
Compound 4: the middle estimate sits 1.1-fold (0.03 log units) below what was measured; low and high end bracket the measured number.
By their numbers in this assay, from the lowest: compounds 1, 3 and 4 (each within the scatter of the next). At a limit, above all of these: compound 2.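

In this assay, removing the hydrogen-bond donor of 4-hydroxyphenyl and adding a heavy atom gives a 1.0-fold higher number from compound 3 to compound 4 (0.01 log units; within the scatter), so this donor makes no detectable difference here. Methoxy in place of fluoro on an aromatic carbon likewise gives a 1.1-fold higher number from compound 1 to compound 4 (0.05 log units; within the scatter), leaving the three aryl sulfonamides indistinguishable. Methyl on the sulfonyl sulfur gives only a limit, and the step to 3-methoxyphenyl is an at least 1.2-fold lower number from compound 2 to compound 4 (0.09 log units; that floor lies within the scatter), so no gain from the aromatic ring can be claimed.

From the compounds shown here alone, whether an amine or a carboxylic acid on that ring would move the number remains open. So does the effect of a longer chain on the sulfonyl sulfur.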